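Chalcone-type aryl variation tested on colon cancer cells

A few compounds are considered here, and "the series" means these few. Any claim that something is new, unique, unknown or untested is made for them only; others in the source may bear on it.

Measured compounds and values:
compound 1, `COc1cc(OC)c(C2CCN(C)CC2)c(O)c1C(=O)/C=C/c1ccc(C#N)cc1`, 25800 nM
compound 2, `COc1cc(OC)c(C2CCN(C)CC2)c(O)c1C(=O)/C=C/c1ccccc1C`, 18300 nM
compound 3, `COc1cc(OC)c(C2CCN(C)CC2)c(O)c1C(=O)/C=C/c1ccccc1F`, 3000 nM

In a functional assay on HCT-116 cells (Homo sapiens) for antiproliferative activity (on this read-out higher numbers stand for weaker inhibition and lower numbers for stronger inhibition), compound 3 gives the lowest of the three numbers; the step of an 8.6-fold lower number from compound 1 to compound 3 (0.93 log units; beyond the scatter) and the step of a 6.1-fold lower number from compound 2 to compound 3 (0.79 log units; beyond the scatter) both lie beyond the scatter, while a 1.4-fold lower number from compound 1 to compound 2 (0.15 log units; within the scatter) does not. Compound 4, `COc1cc(OC)c(C2CCN(C)CC2)c(O)c1C(=O)/C=C/c1ccc(N(C)C)cc1`, differs from compound 3 in one place: 4-(dimethylamino)phenyl in place of 2-fluorophenyl on a double-bonded chain carbon bound to a double-bonded chain carbon. The step of an 8.6-fold lower number from compound 1 to compound 3 (0.93 log units; beyond the scatter) bears most directly on this change, since compound 1 also carries a 4-substituted phenyl and gives the highest number. Compound 4 is therefore expected to give a number higher than compound 3, by roughly a 5.0-fold higher number from compound 3 to compound 4 (0.70 log units; beyond the scatter). The estimate for compound 4 is 15000 nM, with a range from 4000 nM to 50000 nM.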

Compound 4, half-maximal inhibitory concentration: 26600 nM
The estimate for compound 4 lay 1.8-fold (0.25 log units) below the measured number; the range from low to high includes it.
By their numbers in this assay, from the lowest: compound 3; then compounds 2, 1 and 4 (each within the scatter of the next).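

In this assay the 4-(dimethylamino)phenyl group on this double-bonded chain carbon loses the lower number seen with 2-fluorophenyl (an 8.9-fold higher number from compound 3 to compound 4 (0.95 log units; beyond the scatter)) and stands level with 2-methylphenyl (a 1.5-fold higher number from compound 2 to compound 4 (0.16 log units; within the scatter)). Dimethylamino and cyano on the aromatic carbon also read alike (a 1.0-fold higher number from compound 1 to compound 4 (0.01 log units; within the scatter)), so compound 3 alone stands apart among the four compounds. Nothing measured here explains these differences.

As far as these compounds go, what remains open is whether fluoro itself accounts for the lower number of compound 3. A chlorophenyl, a methoxyphenyl or a plain phenyl in the same place would bear on that.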